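Removing a methyl from the amino-linked phenyl ring

This account rests on a few compounds, and the source may have more. Where it says the series, first, only, none or still open, it means among the compounds named here.

Compound 2 `COc1ccc(Nc2nc(-c3ccccc3)c(Cc3c(O)ccc4ccccc34)c(=O)[nH]2)cc1` carries a (4-methoxyphenyl)amino group on the shared core. For the measured compounds named here, in a functional assay on EJ cells (Homo sapiens) for antiproliferative activity, read by MTT assay, with a stated time of 3 h (a lower number here means a stronger inhibitor, a higher number a weaker inhibitor), compound 2 gives 160000 nM, the highest number of the two measured here; its only neighbour, compound 1 `CCN(CC)c1nc(-c2ccccc2)c(Cc2c(O)ccc3ccccc23)c(=O)[nH]1`, gives 15400 nM in this assay. Going by the values given here, the one step known, a 10-fold higher number from compound 1 to compound 2 (1.02 log units; beyond the scatter), swaps the whole group and so does not speak directly to the smaller change now considered. Compound 3 `O=c1[nH]c(Nc2ccc(O)cc2)nc(-c2ccccc2)c1Cc1c(O)ccc2ccccc12` differs from compound 2 by hydrogen in place of methyl on an oxygen on an aromatic ring, that is methoxy becoming hydroxy, 4-methoxyphenyl becoming 4-hydroxyphenyl. Among the compounds with values here, no measured pair shows what such a change does, so the expectation rests on the change being small. Compound 3 is therefore expected to lie near compound 2, with a step of a 1.3-fold lower number from compound 2 to compound 3 (0.12 log units; within the scatter) in this assay that is not beyond the scatter. The estimate for compound 3 in this assay is 120000 nM, within 40000 nM to 400000 nM.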

Compound 3, half-maximal inhibitory concentration: 90900 nM
Compound 3: the middle estimate sits 1.3-fold (0.12 log units) above what was measured, and the stated range covers the measured number.
By their numbers in this assay, from the lowest: compound 1; then compounds 3 and 2 (each within the scatter of the next).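

In this assay, replacing the methyl on the oxygen with hydrogen gives a 1.8-fold lower number from compound 2 to compound 3 (0.25 log units; within the scatter), so this small change to the aromatic ring's substituent has no effect that can be told from assay noise. The larger swap still counts: the data show a 5.9-fold higher number from compound 1 to compound 3 (0.77 log units; beyond the scatter), which leaves compound 1 the strongest of the three, whether the ring carries methoxy or hydroxy. Nothing available explains these numbers.

Open, on these data alone, is whether any group at this place can shift the number beyond the scatter, for example an amine or a carboxylic acid in place of hydroxy, or a longer chain such as ethoxy on the oxygen. Also open, as far as these compounds go, is whether the gap to compound 1 comes from the ring itself, which a simple benzylamino or smaller dialkylamino group could begin to test.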